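A few compounds are considered here, and "the series" means these few. Any claim that something is new, unique, unknown or untested is made for them only; others in the source may bear on it.

Of the compounds shown here, three that share one core have been tested in a functional assay on A549 cells (Homo sapiens) for cytotoxicity, read by MTT assay, with a stated time of 72 h; a higher number here means a weaker inhibitor, a lower number a stronger inhibitor. Compound 1 `COc1ccc(Nc2nc3ccccc3nc2S(=O)(=O)c2ccccc2)cc1` gives 11900 nM in this assay. Compound 2 `COc1cc(Nc2nc3ccccc3nc2S(=O)(=O)c2ccccc2)cc(OC)c1` gives 70 nM in this assay, which is a 170-fold lower number from compound 1 to compound 2 (2.23 log units; beyond the scatter); the structural difference behind that step is 3,5-dimethoxyphenyl in place of 4-methoxyphenyl on a nitrogen on an aromatic ring. Compound 3 `COc1ccc(Nc2nc3ccccc3nc2S(=O)(=O)c2ccc(C)cc2)cc1` rests on a slightly different core, and the two cores differ by methyl in place of hydrogen on an aromatic carbon. For compound 3, this assay reports only a limit, > 50000 nM, which is the limit of > 50000 nM in this assay, at which 1 of the 3 values shown sits. Measured against compound 1, that is an at least 4.2-fold higher number from compound 1 to compound 3 (0.62 log units; beyond the scatter). Compound 4 `COc1cc(Nc2nc3ccccc3nc2S(=O)(=O)c2ccc(C)cc2)cc(OC)c1` has not yet been measured in this assay. Within the data shown here, it differs from compound 3 by 3,5-dimethoxyphenyl in place of 4-methoxyphenyl on a nitrogen on an aromatic ring, the same change at the same place as the one that separates compound 1 from compound 2. A step of an at least 100-fold lower number from compound 3 to compound 4 (2.00 log units; beyond the scatter) is expected in this assay, resting on the step of a 170-fold lower number from compound 1 to compound 2 (2.23 log units; beyond the scatter), although the starting point for compound 3 is only a limit, which leaves the size uncertain. The value expected for compound 4 in this assay is 500 nM, estimated to fall between 100 nM and 5000 nM.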

Compound 4, half-maximal inhibitory concentration: 8060 nM
Beside the measured number, compound 4's estimate is 16-fold (1.21 log units) below it; measured number outside the range, above it.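

In this assay, 3,5-dimethoxyphenyl in place of 4-methoxyphenyl again lowers the number on the core of compound 3, with an at least 6.2-fold lower number from compound 3 to compound 4 (0.79 log units; beyond the scatter), and methyl in place of hydrogen on an aromatic carbon raises the number on the 3,5-dimethoxyphenyl side, with a 120-fold higher number from compound 2 to compound 4 (2.06 log units; beyond the scatter). Compound 3 stands only as a limit, > 50000 nM, and not as a number. The direction of the change therefore carries from one core to the other in these two pairs, but the size of the change on the second core stays unsettled, so nothing can be said about whether it matches the first: the same change on two cores in this assay, a 170-fold lower number (2.23 log units; beyond the scatter) from compound 1 to compound 2 and an at least 6.2-fold lower number (0.79 log units; beyond the scatter) from compound 3 to compound 4; the limit leaves it open whether they differ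

On these data alone, it remains open how a different group on that aromatic carbon, such as an amine or a carboxylic acid in place of the methyl, would alter the number, and whether the 3,5-dimethoxyphenyl change would still lower it there. As far as these compounds go, whether the same steps appear in other cell lines also remains open.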